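The source may hold more compounds than are shown below. What is called first, only, known or untested is meant among the compounds shown, and "the series" means these compounds.

Measured so far in a functional assay on Hs 683 cells (Homo sapiens) for cytotoxicity, read by MTT assay, with a stated time of 72 h; on this read-out lower numbers stand for stronger inhibition and higher numbers for weaker inhibition:
compound 1 `Cc1ccc2[nH]c(-n3cccn3)c(C3=C(Br)C(=O)NC3=O)c2c1` gives 29000 nM;
compound 2 `Cc1ccc2[nH]c3c4cn[nH]c4c4c(c3c2c1)C(=O)NC4=O` gives > 100000 nM, which is a limit of the assay and not a number;
compound 3 `O=C1NC(=O)c2c1c1[nH]ncc1c1[nH]c3ccccc3c21` gives 93000 nM.

Compound 1 stands with the lowest of the two numbers; compound 3 sits at a higher number, beyond the usual scatter. The difference between the core of compound 1 and the core of compound 2 is not broken down here. From compound 2 to compound 3 the change is hydrogen in place of methyl on an aromatic carbon, and the measured step is an at least 1.0-fold lower number from compound 2 to compound 3 (0.03 log units; that floor lies within the scatter), which rests on the limit of > 100000 nM in this assay, at which 1 of the 3 values shown sits, and so says little about direction. The not yet measured compound 4 `O=C1NC(=O)C(c2c(-n3cccn3)[nH]c3ccccc23)=C1Br` differs from compound 1 by hydrogen in place of methyl on an aromatic carbon, the same kind of change, though here the ring is part of a fused or bridged system of two rings rather than five. Because compound 1 gives 29000 nM and the earlier step is only an at least 1.0-fold lower number from compound 2 to compound 3 (0.03 log units; that floor lies within the scatter), the step from compound 1 to compound 4 is expected to be small, estimated at a 1.2-fold higher number from compound 1 to compound 4 (0.08 log units; within the scatter). Compound 4 is accordingly estimated at 35000 nM, with a range from 12000 nM to 100000 nM.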

Compound 4, half-maximal inhibitory concentration: 29000 nM
The estimate for compound 4 lay 1.2-fold (0.08 log units) above the measured number; measured number inside the range.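

In this assay, hydrogen in place of methyl on an aromatic carbon leaves the number unmoved, with no change at the digits printed from compound 1 to compound 4 (within the scatter). Set beside the earlier case, the same change on the two cores reads as follows: the same change on two cores in this assay, an at least 1.0-fold lower number (0.03 log units; that floor lies within the scatter) from compound 2 to compound 3 and no change at the digits printed (within the scatter) from compound 1 to compound 4; the limit leaves it open whether they differ. Among these compounds, compound 2 stands at a limit of the assay and not a number, so only the step on the core of compound 1 has a readable size, and carrying that result to the other core is neither confirmed nor ruled out: the limit of > 100000 nM in this assay, at which 1 of the 4 values shown sits.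

The compounds shown carry only hydrogen or methyl at this place. Going by these compounds, how a chlorine atom, a methoxy group, an amine or a longer chain there would read remains open.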